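Aryl exchange on the carbon double-bonded to nitrogen

A few compounds are considered here, and "the series" means these few. Any claim that something is new, unique, unknown or untested is made for them only; others in the source may bear on it.

Compound 2 `Cc1ccccc1/C(CCN1CCN(c2ccccn2)CC1)=N/O` gives 82% in a functional assay on HEK293 cells with D(4) dopamine receptor (Homo sapiens) as the target, read by FLIPR (on this read-out lower numbers stand for smaller maximal responses and higher numbers for larger maximal responses), the highest of the three numbers measured. Compound 3 `Cc1ccccc1/C(CCN1CCN(c2ccccn2)CC1)=N\O` gives 72% in this assay, and compound 1 `O/N=C(/CCN1CCN(c2ccccn2)CC1)c1ccccc1Cl` gives 64% in this assay. Among the measured compounds shown here, the step of a number 10 percentage points lower from compound 2 to compound 3 (within the scatter) stays within the scatter, because of the fact that compounds 2 and 3 differ only in the configuration as drawn it is the only pure configurational comparison here. The step of a number 8 percentage points higher from compound 1 to compound 3 (within the scatter) also stays within the scatter.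

Compound 4 `O/N=C(\CCN1CCN(c2ccccn2)CC1)c1ccc(F)cc1` is the next compound: 4-fluorophenyl in place of 2-methylphenyl on a carbon with a double bond to nitrogen. For the measured compounds named here, only the step from compound 1 to compound 3 touches the aryl group, and it was within the scatter, so a small step is expected in this assay, if any, most likely downward from the top value of compound 2. Compound 4 is therefore estimated at 72% (range 55% to 90%), an expected step of a number 10 percentage points lower from compound 2 to compound 4 (within the scatter).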

Compound 4, largest response reached (reported as efficacy), in percent of the reference or control that the assay uses: 74%
Compound 4: middle estimate off by 2 percentage points, on the low side, and the stated range covers the measured number.
By their numbers in this assay, from the lowest: compounds 1, 3, 4 and 2 (each within the scatter of the next, the first and the last beyond it).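

The step of a number 8 percentage points lower from compound 2 to compound 4 (within the scatter) in this assay shows that the maximal response at this carbon with a double bond to nitrogen does not depend on 2-methylphenyl, since 4-fluorophenyl serves there as well. This exchange moves further from 2-methylphenyl than the earlier methyl-for-chloro step, yet the result still stays within the scatter. Nothing at hand bears on why this aryl exchange behaves as it does.

Going by these compounds, whether an aryl group is needed at this place remains open, for instance with cyclohexyl or a longer alkyl chain in its place. Also open, on these data alone, is how a carboxylic acid on the phenyl ring would affect the response.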